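A few compounds are considered here, and "the series" means these few. Any claim that something is new, unique, unknown or untested is made for them only; others in the source may bear on it.

In an ADME assay on MCF-10A cells (Homo sapiens) for cytotoxicity, read by MTT assay, with a stated time of 72 h (on this read-out higher numbers stand for weaker inhibition and lower numbers for stronger inhibition), compound 2 (`CCCCOc1ccc(C2=C(c3ccc(O)cc3)[C@H]3C[C@H](S(=O)(=O)N(CC)c4ccccc4)[C@@H]2O3)cc1`) gives 59200 nM. Two close relatives help place that number: compound 1 (`CCCCOc1ccc(C2=C(c3ccc(O)cc3)[C@H]3O[C@@H]2C[C@@H]3S(=O)(=O)N(CC)c2ccccc2)cc1`) gives 32800 nM and compound 3 (`CCCCCCCCOc1ccc(C2=C(c3ccc(O)cc3)[C@H]3O[C@@H]2C[C@@H]3S(=O)(=O)N(CC)c2ccccc2)cc1`) gives 34600 nM. Compound 2 lies within the usual scatter of both, so these three values cannot be ranked with any confidence.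

Compound 4 (`CCCCCCCCOc1ccc(C2=C(c3ccc(O)cc3)[C@H]3C[C@H](S(=O)(=O)N(CC)c4ccccc4)[C@@H]2O3)cc1`) differs from compound 2 by a single change: butyl in place of hydrogen on a saturated chain carbon, four bonds along the chain from an oxygen on an aromatic ring. The butyl replaces a hydrogen on a saturated chain carbon, four bonds along the chain from an oxygen on an aromatic ring.

Going by the values given here, only one measured step bears on this, the same swap made on compound 1. That swap gave a 1.1-fold higher number from compound 1 to compound 3 (0.02 log units; within the scatter), which is within the scatter. One pair is thin evidence, but it offers no reason to expect a real shift in either direction in this assay. The estimated change is a 1.2-fold lower number from compound 2 to compound 4 (0.07 log units; within the scatter), which is expected to stay within the scatter. For compound 4 the expected value is 50000 nM, with an estimated range from 27000 nM to 90000 nM.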

Compound 4, half-maximal inhibitory concentration: 59400 nM
Compound 4: middle estimate off by 1.2-fold (0.07 log units), on the low side, and the stated range covers the measured number.
By their numbers in this assay, from the lowest: compounds 1, 3, 2 and 4 (each within the scatter of the next).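

Adding butyl in place of hydrogen at this position gives a 1.0-fold higher number from compound 2 to compound 4 (0.00 log units; within the scatter) in this assay, so the absence of a real shift seen on the core of compound 1 now appears on a second core as well. Going by these compounds alone, the conclusion therefore no longer rests on a single pair, and the two steps agree with each other: the same change on two cores in this assay, a 1.1-fold higher number (0.02 log units; within the scatter) from compound 1 to compound 3 and a 1.0-fold higher number (0.00 log units; within the scatter) from compound 2 to compound 4, 1.1-fold (0.02 log units) apart, within the scatter of two such steps Across these four compounds, adding butyl at this chain carbon leaves the reading unmoved beyond the scatter on both cores, and no compound goes against that.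

The chains shown at this position are plain carbon chains, so it remains open whether an amine or a carboxylic acid on the chain would move the number. On these data alone, it also remains open whether a still longer chain would leave the number just as unmoved.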